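This account rests on a few compounds, and the source may have more. Where it says the series, first, only, none or still open, it means among the compounds named here.

Measured so far:
- compound 1 `CCC(C)C(NC(=O)n1nnc2ccccc21)C(=O)NC1CCCCC1` — in a functional assay on HEL cells (Homo sapiens) for cytotoxicity (on this read-out higher numbers stand for lower toxicity in this test and lower numbers for higher toxicity in this test), compound 1 gives 80 ug/mL
- compound 2 `O=C1NC(c2ccccc2)C(=O)N1Cc1ccccc1` — in this assay compound 2 gives 100 ug/mL

Two numbers only, and they lie within the usual scatter of each other. Among the measured compounds shown here, compound 2 carries the larger figure of the pair, with compound 1 as its only neighbour, but the gap between them is too small to be read as a real difference in this assay; neither compound can be set above the other on this evidence.

Compound 3 `CCC(C)C1NC(=O)N(Cc2ccccc2)C1=O` is not yet measured. It comes from compound 2 by one change: sec-butyl in place of phenyl on a saturated ring carbon. For the measured compounds named here, no step between measured compounds of this kind is available, so the size and direction of this change cannot be read from the series. Going by the values given here, with compound 1, built on a different core, sitting within the scatter of compound 2, the series so far offers no sign that such substitution moves the read-out of this assay much in either direction.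

Compound 3 is therefore expected to stay close to compound 2 in this assay, with the step of no change at the digits printed from compound 2 to compound 3 (within the scatter) expected to fall within the scatter. The estimate for compound 3 in this assay is 100 ug/mL, with a range from 50 ug/mL to 200 ug/mL.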

Compound 3, minimum cytotoxic concentration: 100 ug/mL
Beside the measured number, compound 3's estimate shows no gap at the digits printed; low and high end bracket the measured number.
By their numbers in this assay, from the lowest: compounds 1, 2 and 3 (each within the scatter of the next).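

On the saturated ring carbon of the five-membered ring, sec-butyl in place of phenyl gives no change at the digits printed from compound 2 to compound 3 (within the scatter) in this assay. Among the compounds shown here, this is the first direct reading at this position, and it shows that a six-membered aromatic ring of carbon only and an open four-carbon group, neither with hydrogen-bond donors or acceptors, can be exchanged here without a difference that this read-out can resolve. No measurement shown gives a reason for this outcome.

A single step between two uncharged carbon-only groups leaves open whether the same holds for an amine, a carboxylic acid or a longer chain on this ring carbon. On these data alone, compound 2 and compound 3 also share the group of 7 heavy atoms on the other ring atom, so the effect of replacing it with, for example, a methyl group remains open, as does whether any change on this core can move the read-out beyond the scatter.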